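Benzamide in place of the aryl urea: compound 3

The source may hold more compounds than are shown below. What is called first, only, known or untested is meant among the compounds shown, and "the series" means these compounds.

Measured compounds:
compound 1 `COc1cc(-c2nn(-c3cccc(NC(=O)Nc4cccc(C(F)(F)F)c4)c3)cc2-c2ccncc2)ccc1Cl` 1190 nM
compound 2 `COc1cc(-c2nn(-c3cccc(NC(=O)Nc4ccc(Cl)c(C(F)(F)F)c4)c3)cc2-c2ccncc2)ccc1Cl` 1550 nM

In a functional assay on HCC 2998 cells (Homo sapiens) for inhibition, read by sulforhodamine B assay, with a stated time of 48 h (a lower number here means a stronger inhibitor of growth, a higher number a weaker inhibitor of growth), compound 2 gives the highest of the two numbers; compound 1 is within the scatter of it, as the step of a 1.3-fold higher number from compound 1 to compound 2 (0.11 log units; within the scatter) shows. Compound 3 `COc1cc(-c2nn(-c3cccc(NC(=O)c4ccccc4)c3)cc2-c2ccncc2)ccc1Cl` differs from compound 2 by phenyl in place of (4-chloro-3-(trifluoromethyl)phenyl)amino on a carbonyl carbon. Among the measured compounds shown here, no measured step touches this change; the only step, from the chloro to the hydrogen, gives no guidance on the urea itself. The change removes more than it adds, so a weaker compound is expected. The estimated step of a 3.2-fold higher number from compound 2 to compound 3 (0.51 log units; beyond the scatter) leads to an expected value for compound 3 of 5000 nM, with a range from 1500 nM to 20000 nM.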

Compound 3, concentration for 50% growth inhibition: 2320 nM
For compound 3 the middle estimate is 2.2-fold (0.33 log units) above the measured one; the measured number falls inside the stated range.
By their numbers in this assay, from the lowest: compounds 1, 2 and 3 (each within the scatter of the next).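

In this assay, replacing the whole arylamino part of the urea with phenyl, which gives a benzamide, stays within the scatter, with a 1.5-fold higher number from compound 2 to compound 3 (0.18 log units; within the scatter) and a 1.9-fold higher number from compound 1 to compound 3 (0.29 log units; within the scatter) as the two steps. The earlier compounds shown here varied only a chloro on the aryl ring, whereas these steps show that the carbonyl carbon can carry phenyl in place of either arylamino group with no difference these numbers can resolve. Nothing measured here explains this result. Still open, on these data alone, is whether an amine or a carboxylic acid on the benzamide phenyl would move the number beyond the scatter.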